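Swapping chloro for methyl on the benzyl ring: expected cytotoxicity

This account rests on a few compounds, and the source may have more. Where it says the series, first, only, none or still open, it means among the compounds named here.

Measured compounds:
- compound 1 `N#Cc1ccc(Nc2nccc(OCc3cccnc3)n2)cc1`: 6400 nM
- compound 2 `N#Cc1ccc(Nc2nccc(OCc3cccc(Cl)c3)n2)cc1`: 153000 nM
- compound 3 `Cc1ccccc1COc1ccnc(Nc2ccc(C#N)cc2)n1`: 12000 nM

In an ADME assay on MT4 cells (Homo sapiens) for cytotoxicity, read by MTT assay, with a stated time of 5 days (on this read-out higher numbers stand for lower toxicity in this test and lower numbers for higher toxicity in this test), compound 2 gives the highest of the three numbers, a step of a 24-fold higher number from compound 1 to compound 2 (1.38 log units; beyond the scatter) and one of a 13-fold lower number from compound 2 to compound 3 (1.11 log units; beyond the scatter) in reverse, both beyond the scatter. Compound 4 `Cc1cccc(COc2ccnc(Nc3ccc(C#N)cc3)n2)c1` differs from compound 2 by methyl in place of chloro on an aromatic carbon, giving 3-methylphenyl in place of 3-chlorophenyl. Within the data shown here, no measured step makes this exact exchange. The nearest is a 13-fold lower number from compound 2 to compound 3 (1.11 log units; beyond the scatter), where methyl also replaces chloro but moves to another ring position; a 1.9-fold higher number from compound 1 to compound 3 (0.27 log units; within the scatter) shows the 2-methylphenyl compound close to the pyridin-3-yl compound. With only these, a moderate step downward from compound 2 is expected, though the large steps seen leave wide room. Compound 4 is therefore estimated at 45000 nM, within 12000 nM to 160000 nM, an expected step of a 3.4-fold lower number from compound 2 to compound 4 (0.53 log units; beyond the scatter).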

Compound 4, half-maximal cytotoxic concentration: 30000 nM
Compound 4: middle estimate off by 1.5-fold (0.18 log units), on the high side; the range from low to high includes it.
By their numbers in this assay, from the lowest: compounds 1 and 3 (each within the scatter of the next); then compound 4; then compound 2.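

In this assay, the exact exchange of chloro for methyl at this ring position now has its own size (a 5.1-fold lower number from compound 2 to compound 4 (0.71 log units; beyond the scatter)), a smaller drop than the one seen when the methyl group sat at another ring position. Where the methyl group sits therefore matters here (a 2.5-fold higher number from compound 3 to compound 4 (0.40 log units; beyond the scatter)), and the 3-methylphenyl group also stands clear of pyridin-3-yl (a 4.7-fold higher number from compound 1 to compound 4 (0.67 log units; beyond the scatter)), whereas the 2-methylphenyl compound, compound 3, stays within the scatter of compound 1. Nothing available gives a reason for these differences.

The compounds shown leave open how other groups at this ring position, such as methoxy, an amine or a carboxylic acid, would read. They also leave open whether chloro, moved to another ring position, would shift the number as methyl does.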